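The source may report more compounds than this note shows. Statements on the series, on what has been measured and on what is new or still open speak of the compounds shown alone.

Compound 1 `COc1ccc(CNc2ncc(C(=O)O)c3nc(-c4ccco4)nn23)cc1OC` is a carboxylic acid carrying a dimethoxybenzyl group on the amine of the shared core; in an assay on CHO cells for displacement of a labelled ligand from adenosine receptor A1 (Homo sapiens) (on this read-out higher numbers stand for weaker inhibition and lower numbers for stronger inhibition), compound 1 gives 958 nM. Two ethyl esters on the same core provide the other numbers: compound 2 `CCOC(=O)c1cnc(NCC2CCCCC2)n2nc(-c3ccco3)nc12` gives 432 nM in this assay, and compound 3 `CCOC(=O)c1cnc(NC2CCCCC2)n2nc(-c3ccco3)nc12` gives 141 nM. Among these three, compound 1 stands highest, and both other numbers lie beyond the scatter from it, so compound 1 is the weakest inhibitor of the set.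

Among the measured compounds shown here, the only one-place step measured so far, a 3.1-fold lower number from compound 2 to compound 3 (0.49 log units; beyond the scatter), concerns the group on the nitrogen and not the aromatic ring, so it does not bear directly on the change now considered. Compound 4 `COc1ccc(CNc2ncc(C(=O)O)c3nc(-c4ccco4)nn23)cc1` differs from compound 1 by hydrogen in place of methoxy on an aromatic carbon. For the measured compounds named here, no measured pair shows what removing a methoxy from that ring does, and the carboxylic acid series has only one member. With nothing to point either way, the expectation for compound 4 is a number close to that of compound 1: the estimated step of a 1.1-fold lower number from compound 1 to compound 4 (0.05 log units; within the scatter) is not expected to exceed the scatter. The estimate for compound 4 in this assay is therefore 850 nM, with a range from 300 nM to 2500 nM.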

Compound 4, inhibition constant: 5760 nM
Beside the measured number, compound 4's estimate is 6.8-fold (0.83 log units) below it, outside the stated range (above it).
By their numbers in this assay, from the lowest: compound 3; then compound 2; then compound 1; then compound 4.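

Taking one methoxy off the dimethoxybenzyl group of this carboxylic acid is not a neutral change: in this assay it gives a 6.0-fold higher number from compound 1 to compound 4 (0.78 log units; beyond the scatter) and so means weaker inhibition. Only two heavy atoms leave, and they sit on an aromatic carbon ortho to a methoxy group and meta to a large group, so this place on the ring matters to the read-out even though the edit is small and the other methoxy stays. Nothing available explains why this methoxy makes such a difference.

The compounds shown leave open whether a methoxy is specifically needed at this place, or whether a hydroxyl, a fluorine or an ethoxy there would restore the lower number seen with compound 1. Also open, on these data alone, is whether the same change would have a similar effect with an ethyl ester in place of the carboxylic acid on the shared core, which would show if this step holds beyond the acid series.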